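A Bromophenyl Urea Takes the Place of an Amide Tail

The source may report more compounds than this note shows. Statements on the series, on what has been measured and on what is new or still open speak of the compounds shown alone.

Among the measured compounds shown here, compound 2 `O=C(CCc1cccc(C(F)(F)F)c1)Nc1cc(Oc2ccc3nc(NC(=O)C4CC4)sc3c2)ccc1F` is the only compound with a number in a functional assay on HT-29 cells (Homo sapiens) for inhibition, read by luminescence and CellTiter-Glo, with a stated time of 12 h (on this read-out lower numbers stand for an effect already at smaller amounts and higher numbers for an effect only at larger amounts of compound), where compound 2 gives 650 nM. Compound 1 `O=C(Nc1nc2ccc(Oc3ccc(F)c(NS(=O)(=O)c4cccc(C(F)(F)F)c4)c3)cc2s1)C1CC1` sits at the limit of > 20000 nM in this assay, at which 1 of the 2 values shown sits, so its result of > 20000 nM is a limit of this assay and not a number. Compound 3 `O=C(Nc1cccc(Br)c1)Nc1cc(Oc2ccc3nc(NC(=O)C4CC4)sc3c2)ccc1F` differs from compound 2 by (3-bromophenyl)amino in place of 2-(3-(trifluoromethyl)phenyl)ethyl on a carbonyl carbon. For the measured compounds named here, no step between measured compounds is available, so the size of the change in this assay is open; a modest shift in either direction, or none beyond the scatter, is expected. Compound 3 is estimated at 400 nM, between 100 nM and 2000 nM, an expected step of a 1.6-fold lower number from compound 2 to compound 3 (0.21 log units; within the scatter).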

Compound 3, half-maximal effective concentration: 440 nM
Compound 3: the middle estimate sits 1.1-fold (0.04 log units) below what was measured; the measured number falls inside the stated range.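

Replacing the amide tail with the urea gives a 1.5-fold lower number from compound 2 to compound 3 (0.17 log units; within the scatter) in this assay. The reading at this carbonyl carbon therefore stays within the scatter when 2-(3-(trifluoromethyl)phenyl)ethyl gives way to (3-bromophenyl)amino, although bromine replaces trifluoromethyl and the amino nitrogen replaces the chain in one change. No measurement shown gives a reason for this outcome.

On these data alone, the separate contributions of the bromine and the amino nitrogen stay open. So does the reading with chlorine, a methoxy group or a carboxylic acid in place of the bromine.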